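Swapping Methyl for Pyridin-4-yl: Expecting No Toxicity Change

The compounds below may be only part of what the source reports. "The series", "measured", "known", "first", "only" and "open" are said of these compounds alone.

Of the compounds shown here, three sharing one core have been tested in an ADME assay on MDBK cells (Bos taurus) for cytotoxicity; a lower number here means that less compound is tolerated, a higher number that more compound is tolerated. Compound 1 `COc1ccc(Cn2ccc3nc(-c4ccccc4)nc-3c2)cc1` gives > 100000 nM, which is a limit of the assay rather than a number. Compound 2 `Fc1ccccc1Cn1ccc2nc(-c3ccccc3)nc-2c1` also reaches only a limit, > 100000 nM. Compound 3 `CCn1ccc2nc(-c3ccccc3)nc-2c1` likewise stops at a limit, > 100000 nM. The three differ only in the group on a saturated chain carbon bound to an aromatic nitrogen, yet the steps between them, a step that the two limits leave unreadable from compound 1 to compound 2, a step that the two limits leave unreadable from compound 1 to compound 3 and a step that the two limits leave unreadable from compound 2 to compound 3, cannot be read because of the limit of > 100000 nM in this assay, at which 3 of the 3 values shown sit. Compound 3 therefore stands where the other two stand: at the limit, with nothing to set it apart.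

Compound 4 `c1ccc(-c2nc3ccn(Cc4ccncc4)cc-3n2)cc1` is not yet measured. It differs from compound 3 in one place: pyridin-4-yl in place of methyl on a saturated chain carbon bound to an aromatic nitrogen. Within the data shown here, none of the measured steps bears on this change with a readable size; they show only that a 4-methoxyphenyl, a 2-fluorophenyl and a methyl group on this carbon all leave the cells untouched up to the limit. The expectation for compound 4 in this assay is therefore no step beyond the scatter, a step that the limit leaves unreadable from compound 3 to compound 4. Compound 4 is estimated at 150000 nM, within a range from 50000 nM to 500000 nM, most likely reported once more as a limit.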

Compound 4, half-maximal cytotoxic concentration: > 100000 nM
Compound 4 was reported as a limit (the forecaster's own chance of this, stated with the estimate: 85%); the middle value does not contradict the limit.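

In this assay compound 4 gives > 100000 nM, which is a limit and not a number. Among these compounds, no step between compound 4 and compound 1, compound 2 or compound 3 can be read, because all four stop at the same point: the limit of > 100000 nM in this assay, at which 4 of the 4 values shown sit. The compounds shown leave open whether any group on this carbon would give a readable value.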